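Replacing 3-methoxyphenyl with 4-fluorophenyl on compound 2

The source may hold more compounds than are shown below. What is called first, only, known or untested is meant among the compounds shown, and "the series" means these compounds.

Measured so far in a functional assay on MCF7 cells (Homo sapiens) for cytotoxicity, with a stated time of 48 h; on this read-out higher numbers stand for weaker inhibition and lower numbers for stronger inhibition:
Compound 1 `COc1cc(O)c(C(=O)/C=C/c2ccc(F)cc2)c(OC)c1` gives 8800 nM
Compound 2 `COc1cccc(/C=C/C(=O)c2c(OC)cc(OC)cc2OC)c1` gives 9400 nM

These two values lie within the usual scatter of each other, so compound 2 stands level with compound 1. Compound 3 `COc1cc(OC)c(C(=O)/C=C/c2ccc(F)cc2)c(OC)c1` differs from compound 2 by a single change, (4-fluorophenyl in place of 3-methoxyphenyl on a double-bonded chain carbon bound to a double-bonded chain carbon), with 4-fluorophenyl in place of 3-methoxyphenyl. Compound 1 also carries 4-fluorophenyl and gives 8800 nM in the same range as compound 2, so no step beyond the scatter is expected in this assay for this change. The expected step of a 1.1-fold lower number from compound 2 to compound 3 (0.04 log units; within the scatter) is estimated to be small. For compound 3 the estimate is 8500 nM with an expected range from 3500 nM to 20000 nM in this read-out.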

Compound 3, half-maximal inhibitory concentration: 7700 nM
Beside the measured number, compound 3's estimate is 1.1-fold (0.04 log units) above it; the measured number falls inside the stated range.
By their numbers in this assay, from the lowest: compounds 3, 1 and 2 (each within the scatter of the next).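

In this assay, 4-fluorophenyl in place of 3-methoxyphenyl on a double-bonded chain carbon bound to a double-bonded chain carbon gives a 1.2-fold lower number from compound 2 to compound 3 (0.09 log units; within the scatter) and so does not separate these two groups at this place. Methyl in place of hydrogen on an oxygen on an aromatic ring gives a 1.1-fold lower number from compound 1 to compound 3 (0.06 log units; within the scatter) and likewise stays within the scatter. Nothing available explains these results. Still open, as far as these compounds go, is whether an amine or a carboxylic acid at this chain carbon would give a step beyond the scatter.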